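This account rests on a few compounds, and the source may have more. Where it says the series, first, only, none or still open, it means among the compounds named here.

Compound 1 `CC(C)C(NC(=O)NO)C(=O)NC1CCCC1` gives > 100000 nM in a functional assay on MCF7 cells (Homo sapiens) for inhibition (on this read-out lower numbers stand for stronger inhibition and higher numbers for weaker inhibition), which is a limit of the assay and not a number, so that compound 1 sits at the limit of > 100000 nM in this assay, at which 1 of the 2 values shown sits. Among the measured compounds shown here, compound 2 `O=C1NC(c2ccccc2)C(=O)N1Cc1ccccc1` gives 3300 nM in this assay, and this is the only numerical value shown, so nothing measured stands beside it for comparison. Compound 3 `CCC(C)C1NC(=O)N(Cc2ccccc2)C1=O` has not yet been measured. It differs from compound 2 by sec-butyl in place of phenyl on a saturated ring carbon, while the rest of the shared core stays the same. No measured step of this kind exists among the shown compounds, so the size of the change remains open. A modest weakening is expected, estimated as a 2.4-fold higher number from compound 2 to compound 3 (0.38 log units; beyond the scatter). For compound 3 the expected value in this assay is 8000 nM, within a range from 2000 nM to 40000 nM.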

Compound 3, half-maximal inhibitory concentration: 29500 nM
The estimate for compound 3 lay 3.7-fold (0.57 log units) below the measured number, within the range that was stated.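

At this saturated ring carbon the group matters: in this assay, sec-butyl in place of phenyl gives an 8.9-fold higher number from compound 2 to compound 3 (0.95 log units; beyond the scatter). The step lies beyond the scatter, so with the rest of the shared core unchanged, compound 2 with its phenyl is the stronger of the pair, although compound 3, with no ring in this group, still gives a number and not a limit. Nothing measured on these compounds accounts for the size of this step.

Among the compounds shown here, the single step cannot separate the loss of the aromatic ring from the change in the number of heavy atoms, and a cyclohexyl group at this position would speak to that. From the compounds shown here alone, whether a shorter chain such as methyl or an amine-bearing chain would be weaker still remains open.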